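The source may report more compounds than this note shows. Statements on the series, on what has been measured and on what is new or still open speak of the compounds shown alone.

Measured so far:

- Compound 1 `CN(C)/N=N/c1cccc(C(N)=O)c1`: 3.8
- Compound 2 `COC(=O)c1cccc(/N=N/N(C)C)c1`: 3.42
- Compound 3 `CN(Cc1ccccc1)/N=N/c1nc[nH]c1C(N)=O`: 3.43

In a functional assay on L1210 cells (Mus musculus) for antiproliferative activity (a higher number here means a more potent compound, by a factor of ten per unit of this negative logarithm, a lower number a less potent compound), compound 2 gives the lowest number of the three measured. Compound 3 sits next to it, within the scatter of the assay. Compound 1 is furthest away, and the difference a number 0.38 log units lower from compound 1 to compound 2 (beyond the scatter) is beyond the scatter.

Compound 4 `CC(=O)c1cccc(/N=N/N(C)C)c1` has not yet been measured. It differs from compound 2 in one place: methyl in place of methoxy on a carbonyl carbon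

Within the data shown here, only one measured step touches the same place on the shared core, that from compound 1 to compound 2, and it concerns a different pair of groups. It was modest, a number 0.38 log units lower from compound 1 to compound 2 (beyond the scatter). Nothing measured speaks directly to methyl in place of methoxy on a carbonyl carbon. Among the measured compounds shown here, the series so far spans a narrow band in this assay, so an outcome near compound 2 is the plainest expectation, with no step beyond the scatter in either direction.

For compound 4 the estimate in this assay is 3.4, ranging from 3 to 3.8. The expected step is a number 0.02 log units lower from compound 2 to compound 4 (within the scatter).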

Compound 4, logarithm of the reciprocal of the active concentration, log(1/C): 3.58
Beside the measured number, compound 4's estimate is 0.18 log units below it; measured number inside the range.
By their numbers in this assay, from the lowest: compounds 2, 3, 4 and 1 (each within the scatter of the next, the first and the last beyond it).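

In this assay, among these compounds, the change from methoxycarbonyl to acetyl gives a number 0.16 log units higher from compound 2 to compound 4 (within the scatter) and so does not separate the two compounds, which the earlier compounds could not show, as their only step at this carbonyl carbon concerned amino and methoxy. Methyl in place of amino gives a number 0.22 log units lower from compound 1 to compound 4 (within the scatter) while methoxy in place of amino gave a number 0.38 log units lower from compound 1 to compound 2 (beyond the scatter) and so compound 4 lies within the scatter of both compound 1 and compound 2, leaving no clean split among the three groups on this carbonyl carbon. No measurement available here accounts for these small differences.

On these data alone, it remains open whether a carboxylic acid, a methylamino group or a longer chain such as ethyl on this carbonyl carbon would stay within the same narrow range. As far as these compounds go, it also remains open whether the methoxy to methyl change would read the same way on another core, such as that of compound 3.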